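The source may report more compounds than this note shows. Statements on the series, on what has been measured and on what is new or still open speak of the compounds shown alone.

Compound 1 `CCCN(CC[C@H](N)C(=O)O)C[C@H]1O[C@@H](n2cnc3c(N)ncnc32)[C@H](O)[C@@H]1O` carries a propyl group on the amine nitrogen; in an assay for inhibition of tRNA (cytosine(38)-C(5))-methyltransferase (Homo sapiens), with a stated time of 5 min, tested at 100 uM (a lower number here means less inhibition, a higher number more inhibition at the concentration tested (going by the name of the read-out)), compound 1 gives no result reported. Compound 2 `Nc1ncnc2c1ncn2[C@@H]1O[C@H](CN(CC[C@H](N)C(=O)O)CC2CCC2)[C@@H](O)[C@H]1O` gives 32% in this assay. Within the data shown here, compound 3 `C#CCN(CC[C@H](N)C(=O)O)C[C@H]1O[C@@H](n2cnc3c(N)ncnc32)[C@H](O)[C@@H]1O` gives 72.2% in this assay, the highest of the two numbers so far; its nearest neighbour is compound 2, and the step of a number 40.2 percentage points higher from compound 2 to compound 3 (beyond the scatter) is the only measured step. Compound 4 `C#CC(C)(C)N(CC[C@H](N)C(=O)O)C[C@H]1O[C@@H](n2cnc3c(N)ncnc32)[C@H](O)[C@@H]1O` is not yet measured in this assay; the change from compound 3 is 1,1-dimethylprop-2-yn-1-yl in place of propargyl on an amine nitrogen. Among the measured compounds shown here, no measured step shows this exact change. For the measured compounds named here, the one step that bears on it, a number 40.2 percentage points higher from compound 2 to compound 3 (beyond the scatter), replaced a larger group bound to the amine nitrogen with a smaller one and raised inhibition strongly; the change to compound 4 goes the other way, adding two methyl groups to the carbon bound to the nitrogen while keeping the triple bond. A step in this assay of moderate size downward, beyond the scatter, is therefore expected, so that compound 4 is expected to give 45%, within 20% to 70%. The step of a number 27.2 percentage points lower from compound 3 to compound 4 (beyond the scatter) is the expected outcome of this change.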

Compound 4, a percentage reported as inhibition, at one concentration (the size of the read-out at that concentration, not a potency): 17.3%
The estimate for compound 4 lay 27.7 percentage points above the measured number; the whole stated range lies above it.
By their numbers in this assay, from the lowest: compound 4; then compound 2; then compound 3.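

Replacing propargyl with 1,1-dimethylprop-2-yn-1-yl on the amine nitrogen keeps the triple bond, yet a number 54.9 percentage points lower from compound 3 to compound 4 (beyond the scatter) in this assay shows that a triple bond in this group is not enough to keep the inhibition of compound 3. The same group also falls short of cyclobutylmethyl, with a number 14.7 percentage points lower from compound 2 to compound 4 (beyond the scatter) in this assay, so the earlier step from a larger group to propargyl does not extend to a simple rule that any group with a triple bond beats cyclobutylmethyl at this position; compound 4 goes against such a rule. No evidence is available on why these substituents differ in this way.

Going by these compounds, with no number for the propyl group of compound 1, the comparison of propargyl with a saturated chain on this nitrogen cannot be read, so the part played by the triple bond itself stays open. Also open, on these data alone, is whether the loss in compound 4 already appears with 1-methylprop-2-yn-1-yl, which carries a single methyl group, or whether a longer chain such as but-3-yn-1-yl would keep the inhibition seen with propargyl.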